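The compounds below may be only part of what the source reports. "The series", "measured", "known", "first", "only" and "open" are said of these compounds alone.

Measured compounds:
compound 1, `CC(=O)Nc1nn(-c2ccccc2)c(=O)c2ccccc12`: 0%
compound 2, `O=C(Nc1ccc(Cl)cc1)Nc1nn(-c2ccccc2)c(=O)c2ccccc12`: 13%
compound 3, `COc1ccc(C(=O)Nc2nn(-c3ccccc3)c(=O)c3ccccc23)cc1`: 10%

In an assay on CHO cells for displacement of a labelled ligand from adenosine receptor A3 (Homo sapiens), tested at 1 uM (on this read-out lower numbers stand for less inhibition and higher numbers for more inhibition at the one concentration tested (going by the name of the read-out)), the three compounds share one core and differ only in the group attached to the carbonyl carbon. Compound 2 gives the highest of the three numbers: the step is a number 13 percentage points higher from compound 1 to compound 2 (beyond the scatter), while compound 3 lies close to it, with a number 3 percentage points lower from compound 2 to compound 3 (within the scatter), and compound 3 against compound 1 shows a number 10 percentage points higher from compound 1 to compound 3 (within the scatter).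

Compound 4, `COc1ccc(NC(=O)Nc2nn(-c3ccccc3)c(=O)c3ccccc23)c(OC)c1`, keeps the urea of compound 2 and changes the aryl group on the far nitrogen: 2,4-dimethoxyphenyl in place of 4-chlorophenyl on an amide-type nitrogen. For the measured compounds named here, none of the measured steps alters this aryl group; they only swap the whole substituent on the carbonyl carbon. The step of a number 13 percentage points higher from compound 1 to compound 2 (beyond the scatter) shows that adding the urea matters, while a number 3 percentage points lower from compound 2 to compound 3 (within the scatter) shows that trading it for a 4-methoxyphenyl amide made no difference beyond the scatter. With nothing bearing directly on the aryl swap, no step beyond the scatter is expected in this assay. Compound 4 is therefore estimated at 12%, between 0% and 28%, which is expected to mean a step of a number 1 percentage points lower from compound 2 to compound 4 (within the scatter).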

Compound 4, a percentage reported as inhibition, at one concentration (the size of the read-out at that concentration, not a potency): 33%
For compound 4 the middle estimate is 21 percentage points below the measured one; the measured number lies above the stated range.
By their numbers in this assay, from the lowest: compounds 1, 3 and 2 (each within the scatter of the next, the first and the last beyond it); then compound 4.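

In this assay, the aryl group on an amide-type nitrogen turns out to matter: with 2,4-dimethoxyphenyl in place of 4-chlorophenyl, the result is a number 20 percentage points higher from compound 2 to compound 4 (beyond the scatter). For the compounds shown here, the earlier compounds swapped the whole substituent on the carbonyl carbon, so this is the first sign that changing only the aryl group, while the urea stays, can shift the number beyond the scatter. No measured information is available to explain this shift.

This single swap removes the chlorine and adds both methoxy groups at once, so the compounds shown cannot tell which of these changes matters. They also leave open how a plain phenyl, a 2-methoxyphenyl or a phenyl carrying a carboxylic acid would behave on that nitrogen.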